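The source may hold more compounds than are shown below. What is called first, only, known or untested is meant among the compounds shown, and "the series" means these compounds.

Measured so far in an ADME assay on HepG2 cells (Homo sapiens) for inhibition, read by resazurin assay, with a stated time of 48 h; on this read-out lower numbers stand for an effect already at smaller amounts and higher numbers for an effect only at larger amounts of compound:
- Compound 1 `O=C(Nc1ccc2sc(-c3ccccc3)nc2c1)c1cccs1`: > 50000 nM
- Compound 2 `O=C(Nc1ccc2sc(-c3ccccc3F)nc2c1)N1CCCC1`: > 50000 nM
- Compound 3 `O=C(Nc1ccc2sc(-c3ccc(F)c(F)c3)nc2c1)N1CCCCC1`: > 50000 nM

Each of these readings is a limit of the assay and not a number. The three compounds therefore offer no graded series, and (the limit of > 50000 nM in this assay, at which 3 of the 3 values shown sit). Within the data shown here, compound 2 stands at that same limit, with > 50000 nM as its only reading in this assay.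

The next compound to be measured is compound 4 `O=C(Nc1ccc2sc(-c3cccc(F)c3)nc2c1)N1CCCC1`. It has the same atoms as compound 2, joined differently: 3-fluorophenyl takes the place of 2-fluorophenyl on an aromatic carbon of a five-membered aromatic ring with 1 nitrogen and 1 sulfur (3-fluorophenyl in place of 2-fluorophenyl on an aromatic carbon). Among the measured compounds shown here, no measured pair of compounds shows the size of a comparable change, so any expectation has to rest on the shared limit alone. Nothing in the three readings points to a change in either direction. The expected step is a number no higher from compound 2 to compound 4 (the limit leaves the size open), which would be none beyond the usual scatter. For compound 4 the estimated value is 50000 nM, with an expected range from 25000 nM to 100000 nM.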

Compound 4, half-maximal effective concentration: > 50000 nM
Compound 4 gave a limit, no number; the forecaster's own chance of this, stated with the estimate: 85%; the middle value lies on the limit itself.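

In this assay compound 4 gives > 50000 nM as a limit of the assay and not a number. Compound 2 also gives a limit, so no step can be read between compound 2 and compound 4; the four compounds share one reading: the limit of > 50000 nM in this assay, at which 4 of the 4 values shown sit. The compounds shown leave open whether 2-fluorophenyl and 3-fluorophenyl differ at all on this read-out.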